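Swapping trifluoromethyl for hydroxy on a fluorinated analogue

The source may hold more compounds than are shown below. What is called first, only, known or untested is meant among the compounds shown, and "the series" means these compounds.

Compound 1 `O=C(/C=C\Nc1ccc(C(F)(F)F)cc1)c1cn(-c2ccccc2)nc1-c1ccccc1` in a functional assay on A549 cells (Homo sapiens) for antiproliferative activity, read by MTT assay, with a stated time of 48 h (a higher number here means a weaker inhibitor, a lower number a stronger inhibitor), gives > 50000 nM, which is a limit of the assay, not a number.
Compound 2 `O=C(/C=C\Nc1ccc(O)cc1)c1cn(-c2ccccc2)nc1-c1ccccc1` in this assay gives 3210 nM.
Compound 3 `O=C(/C=C\Nc1ccc(C(F)(F)F)cc1)c1cn(-c2ccccc2)nc1-c1ccc(F)cc1` in this assay gives > 50000 nM, again a limit of the assay.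

Among the compounds with values here, two of the three measured values sit at the same limit, (the limit of > 50000 nM in this assay, at which 2 of the 3 values shown sit), so only one number is in hand. The change from compound 1 to compound 2 is hydroxy in place of trifluoromethyl on an aromatic carbon, and it gave an at least 15-fold lower number from compound 1 to compound 2 (1.19 log units; beyond the scatter). Compound 3 differs from compound 1 in its core by fluoro in place of hydrogen on an aromatic carbon, a step whose size is a step that the two limits leave unreadable from compound 1 to compound 3.

Compound 4 `O=C(/C=C\Nc1ccc(O)cc1)c1cn(-c2ccccc2)nc1-c1ccc(F)cc1` is not yet measured. It stands to compound 3 as compound 2 stands to compound 1: the change is hydroxy in place of trifluoromethyl on an aromatic carbon, the same change made at the same place. Within the data shown here, the only measured example of this change, from compound 1 to compound 2, was large, so a step of similar direction is expected, an at least 12-fold lower number from compound 3 to compound 4 (1.09 log units; beyond the scatter), with the caution that compound 3 begins at a limit and the step cannot be read exactly. Compound 4 is therefore estimated at 4000 nM in this assay, between 1500 nM and 15000 nM.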

Compound 4, half-maximal inhibitory concentration: 1500 nM
Compound 4: middle estimate off by 2.7-fold (0.43 log units), on the high side, within the range that was stated.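

In this assay, hydroxy in place of trifluoromethyl on the fluorinated core gave an at least 33-fold lower number from compound 3 to compound 4 (1.52 log units; beyond the scatter), so the direction seen on the core of compound 1 carried over to a second core. Compound 3 sits at a limit of the assay, so this does not show whether the step has the same size on both cores: the same change on two cores in this assay, an at least 15-fold lower number (1.19 log units; beyond the scatter) from compound 1 to compound 2 and an at least 33-fold lower number (1.52 log units; beyond the scatter) from compound 3 to compound 4; the limit leaves it open whether they differ The fluoro that separates the two cores can be read only with hydroxy in place, as a 2.1-fold lower number from compound 2 to compound 4 (0.33 log units; beyond the scatter), a modest step, while the matching step with trifluoromethyl cannot be read, as both of its ends are limits.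

The compounds shown leave open whether hydroxy is special or whether an amine, a methoxy group or a carboxylic acid on the same aromatic carbon would also give a lower number. Within the data shown here, with only two cores in hand, they also leave open whether the change would carry to a core with, say, chloro in place of the fluoro.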